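From methanesulfonamido to ureido at the chain end

The compounds below may be only part of what the source reports. "The series", "measured", "known", "first", "only" and "open" are said of these compounds alone.

In a functional assay on MDA-MB-231 cells (Homo sapiens) for antiproliferative activity, read by MTT assay, with a stated time of 72 h (on this read-out higher numbers stand for weaker inhibition and lower numbers for stronger inhibition), compound 2 `CS(=O)(=O)Nc1ccc(NC(=O)Nc2cccc(-c3nc(-c4ccc(NC(=O)c5cccnc5)cc4Cl)no3)c2)cc1C(F)(F)F` gives 700 nM. Among the compounds with values here, only one other number exists: compound 1 `CS(=O)(=O)Nc1ccc(NC(=O)Nc2cccc(-c3nc(-c4ccc(NC(=O)c5cccnc5)cc4Cl)no3)c2)cc1` gives 600 nM in this assay, and the step of a 1.2-fold higher number from compound 1 to compound 2 (0.07 log units; within the scatter) lies within the scatter, so the two cannot be told apart. Compound 3 `NC(=O)Nc1ccc(NC(=O)Nc2cccc(-c3nc(-c4ccc(NC(=O)c5cccnc5)cc4Cl)no3)c2)cc1C(F)(F)F` differs from compound 2 by carbamoyl in place of methylsulfonyl on a nitrogen on an aromatic ring. Within the data shown here, no measured step touches this place; the one known step changes a different part and was itself within the scatter. The step of a 1.1-fold higher number from compound 2 to compound 3 (0.06 log units; within the scatter) is therefore expected to stay within the scatter. Compound 3 is estimated at 800 nM, with a range from 300 nM to 2500 nM.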

Compound 3, half-maximal inhibitory concentration: 3400 nM
Compound 3: middle estimate off by 4.3-fold (0.63 log units), on the low side, and the stated range ends below it.
By their numbers in this assay, from the lowest: compounds 1 and 2 (each within the scatter of the next); then compound 3.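

Replacing methanesulfonamido with ureido in this assay gives a 4.9-fold higher number from compound 2 to compound 3 (0.69 log units; beyond the scatter) and so weakens inhibition modestly, but beyond the scatter. Unlike the trifluoromethyl step between the earlier compounds, this change can be told apart from repeat-measurement noise, so this position does respond to what is placed on the nitrogen. Nothing available gives a reason for this step. Whether any replacement for methylsulfonyl would do the same stays open, since the compounds shown include no amine or longer sulfonyl chain here. Going by these compounds, whether ureido behaves alike without trifluoromethyl also stays open.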